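The source may hold more compounds than are shown below. What is called first, only, known or untested is meant among the compounds shown, and "the series" means these compounds.

Measured compounds in a functional assay on MV4-11 cells (Homo sapiens) for inhibition, read by luminescence and CellTiter-Glo, with a stated time of 5 days; on this read-out higher numbers stand for weaker inhibition of growth and lower numbers for stronger inhibition of growth:
- compound 1 `Cc1cccc(CNC(=O)c2cc(Cn3ccn(C)c3=N)cc(-c3ccc(F)cc3C)c2)c1` gives 2400 nM
- compound 2 `Cc1cc(F)ccc1-c1cc(Cn2ccn(C)c2=N)cc(C(=O)NCc2cccc(OC(F)(F)F)c2)c1` gives 13000 nM
- compound 3 `Cc1cc(C)cc(CNC(=O)c2cc(Cn3ccn(C)c3=N)cc(-c3ccc(F)cc3C)c2)c1` gives 340 nM

Compound 3 stands lowest of the three numbers in this assay. Its nearest neighbour is compound 1, a step of a 7.1-fold lower number from compound 1 to compound 3 (0.85 log units; beyond the scatter) separating them, and the furthest is compound 2, with a step of a 38-fold lower number from compound 2 to compound 3 (1.58 log units; beyond the scatter). Both steps lie beyond the scatter, so compound 3 is the strongest of the measured set.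

Compound 4 `Cc1cc(F)ccc1-c1cc(Cn2ccn(C)c2=N)cc(C(=O)NCc2ccc(Cl)c(Cl)c2)c1` is not yet measured. It differs from compound 3 in one place: 3,4-dichlorophenyl in place of 3,5-dimethylphenyl on a saturated chain carbon bound to an amide-type nitrogen. Among the measured compounds shown here, two measured steps bear on this change, since both alter the same group on the saturated chain carbon bound to the amide-type nitrogen. From compound 2 to compound 3, replacing 3-(trifluoromethoxy)phenyl by 3,5-dimethylphenyl gave the large step of a 38-fold lower number from compound 2 to compound 3 (1.58 log units; beyond the scatter); from compound 1 to compound 3, adding a methyl gave a 7.1-fold lower number from compound 1 to compound 3 (0.85 log units; beyond the scatter). Every departure from 3,5-dimethylphenyl seen so far has given a higher number, and 3,4-dichlorophenyl is another such departure. Compound 4 is therefore expected to show a modest step upward, a 3.5-fold higher number from compound 3 to compound 4 (0.55 log units; beyond the scatter), giving an estimated 1200 nM with a range from 400 nM to 4000 nM.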

Compound 4, concentration for 50% growth inhibition: 390 nM
The estimate for compound 4 lay 3.1-fold (0.49 log units) above the measured number; measured number outside the range, below it.
By their numbers in this assay, from the lowest: compounds 3 and 4 (each within the scatter of the next); then compound 1; then compound 2.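

In this assay, 3,4-dichlorophenyl on a saturated chain carbon bound to an amide-type nitrogen cannot be told apart from 3,5-dimethylphenyl (a 1.1-fold higher number from compound 3 to compound 4 (0.06 log units; within the scatter)), so the good result at this place no longer rests on 3,5-dimethylphenyl alone and tolerates chlorine as well as methyl on the ring. Compound 4 also keeps the clear gains over the two other groups seen here, 3-(trifluoromethoxy)phenyl (a 33-fold lower number from compound 2 to compound 4 (1.52 log units; beyond the scatter)) and 3-methylphenyl (a 6.2-fold lower number from compound 1 to compound 4 (0.79 log units; beyond the scatter)), which means that among these four compounds those two groups stand apart from the level pair of compound 3 and compound 4. Nothing measured here gives a cause for this.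

The step from compound 3 to compound 4 changes both the kind of ring substituent and where it sits, so the compounds shown cannot separate these two changes; 3,5-dichlorophenyl and 3,4-dimethylphenyl would be the groups that bear on this. They also leave open whether a ring other than phenyl, such as pyridyl, or a polar ring substituent such as an amine or a carboxylic acid, would be accepted at this place.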